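From a Bromo to a Benzyloxy Substituent

The source may hold more compounds than are shown below. What is called first, only, known or untested is meant among the compounds shown, and "the series" means these compounds.

Of the compounds shown here, three have so far been tested in an assay on HEK293 cells for binding affinity to 5-hydroxytryptamine receptor 7 (Homo sapiens), read by radioligand binding, tested at 1 uM; a higher number here means more inhibition at the concentration tested (going by the name of the read-out), a lower number less inhibition. Compound 1, with the structure `CC1CN(CCn2ccc3ccc(Br)cc32)CCN1`, gives 52%. Compound 2, with the structure `Brc1ccc2ccn(CCN3CCN4CCCC4C3)c2c1`, gives 72%. Compound 3, with the structure `CN1CCCN(CCn2ccc3ccc(Br)cc32)CC1`, gives 93%, the highest of the three numbers; compound 2 stands nearest to it, lower by more than the usual scatter, and compound 1 stands furthest below, also beyond the scatter.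

Compound 4, with the structure `CN1CCCN(CCn2ccc3ccc(OCc4ccccc4)cc32)CC1`, is not yet measured. It differs from compound 3 in one place: benzyloxy in place of bromo on an aromatic carbon. Going by the values given here, no pair of measured compounds shares a single change, so the size of such a swap cannot be read from the numbers in hand. Because compound 3 already sits at 93%, little room remains above it, and a modest downward step in this assay is expected rather than a gain. Compound 4 is therefore expected to give 78%, within a range from 50% to 96%. This amounts to an estimated step of a number 15 percentage points lower from compound 3 to compound 4 (beyond the scatter).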

Compound 4, a percentage reported as inhibition, at one concentration (the size of the read-out at that concentration, not a potency): 28%
Compound 4: middle estimate off by 50 percentage points, on the high side, and the stated range ends above it.
By their numbers in this assay, from the lowest: compound 4; then compound 1; then compound 2; then compound 3.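

On this aromatic carbon of the shared core, replacing bromo (1 heavy atom) with benzyloxy (8 heavy atoms, including a six-membered aromatic ring) is far from a neutral swap: in this assay it gives a number 65 percentage points lower from compound 3 to compound 4 (beyond the scatter). Going by these compounds alone, this is the first step in the set that isolates a single change, and it shows that, with the rest of compound 3 held fixed, the group at this one place can remove most of the inhibition seen at the concentration tested. Nothing in hand explains why the number falls.

As far as these compounds go, it remains open how methoxy, which keeps the oxygen without the benzyl part, or a phenyl ring joined directly without the oxygen, would read at this place. From the compounds shown here alone, it is also open whether benzyloxy would bring a similar step on the side chains of compound 1 or compound 2.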